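The compounds below may be only part of what the source reports. "The series", "measured", "known", "first", "only" and "open" are said of these compounds alone.

In an ADME assay on liver (Mus musculus) for metabolic stability, read by LC-MS, using microsomes and NADPH (a higher number here means that more of the compound is left, a lower number that less of the compound is left), compound 2 `COc1cc(CN(CC(C)C)C(CC(=O)O)c2ccc(Cl)c(Cl)c2)ccc1OCCN1C(=O)CCC1=O` gives 49% as the higher of two numbers, and compound 1 `Cc1cc(CN(C2CCC2)C(CC(=O)O)c2ccc(Cl)cc2)ccc1OCCn1c(=O)ccn(C)c1=O` gives 22% in the same read-out. The gap between these two numbers lies beyond the scatter. The two differ in more than one place, so their gap does not isolate any single change. Compound 3 `COc1cc(CN(CC(C)C)C(CC(=O)O)c2ccc(Cl)c(F)c2)ccc1OCCN1C(=O)CCC1=O` carries fluoro in place of chloro on an aromatic carbon, ortho to a chloro group (fluoro in place of chloro on an aromatic carbon). Among the compounds with values here, no single-place step between measured compounds is available to guide this, and the expected change (a number 3 percentage points higher from compound 2 to compound 3 (within the scatter)) lies within the scatter. In this assay compound 3 is estimated at 52% (expected range 35% to 69%).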

Compound 3, percent of the compound remaining: 57%
Compound 3: the middle estimate sits 5 percentage points below what was measured; the measured number falls inside the stated range.
By their numbers in this assay, from the lowest: compound 1; then compounds 2 and 3 (each within the scatter of the next).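

In this assay the series gains its first single-place step, a number 8 percentage points higher from compound 2 to compound 3 (within the scatter), so 3,4-dichlorophenyl to 4-chloro-3-fluorophenyl gives no readable change in percent remaining. At this position, ortho to a chloro group, chloro and fluoro cannot be told apart in this read-out. No available measurement bears on the reason for this step.

Going by these compounds, whether a nitrile or trifluoromethyl at this position would stay within the scatter remains open. Compound 1 differs from both others in more than one place, so its steps to them cannot be read.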